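The source may report more compounds than this note shows. Statements on the series, on what has been measured and on what is new or still open speak of the compounds shown alone.

Measured so far in an ADME assay on the whole organism with Oryza sativa as the target, tested at 0.1 uM; a lower number here means a stronger effect, a higher number a weaker effect of the compound at the concentration tested:
compound 1 `C[C@H](NC(=O)Nc1ccccc1Cl)c1ccccc1`: 99%
compound 2 `C[C@@H](NC(=O)Nc1c(Cl)cccc1Cl)c1ccccc1`: 100%

Compound 2 gives the higher of the two numbers in this assay, but its gap to compound 1 lies within the scatter, so the two read alike and neither can be ranked above the other. Compound 3 `C[C@H](NC(=O)Nc1c(Cl)cccc1Cl)c1ccccc1` is the next entry. How it differs from compound 2: the two compounds have the same atoms and bonds and differ only in configuration as drawn: 1 of 1 stereo elements differ; a stereocentre at a saturated chain carbon is drawn R in compound 2 and S in compound 3. Within the data shown here, no step between measured compounds bears on such a change, so its size is unknown from these data. Compound 3 is expected to stay near the top of the scale in this assay, with a step of a number 2 percentage points lower from compound 2 to compound 3 (within the scatter) and an estimate of 98%, ranging from 90% to 100%.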

Compound 3, a percentage reported as activity, at one concentration (the size of the read-out at that concentration, not a potency): 100%
Compound 3: the middle estimate sits 2 percentage points below what was measured; low and high end bracket the measured number.
By their numbers in this assay, from the lowest: compounds 1, 2 and 3 (each within the scatter of the next).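

In this assay, among these compounds, changing the stereocentre at the saturated chain carbon from R to S gives no change at the digits printed from compound 2 to compound 3 (within the scatter), the first reading of configuration. The pair isolates that single change: the fact that compounds 2 and 3 differ only in the configuration as drawn. Chloro in place of hydrogen on an aromatic carbon gives a number 1 percentage points higher from compound 1 to compound 3 (within the scatter), so neither change separates the compounds in this assay.

On these data alone, all three compounds read alike near the top of the scale, so it remains open what could lower the number. As far as these compounds go, whether an amine or a carboxylic acid on the shared core would do so also remains open.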